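Methyl on the Aromatic Ring, Tested Again

This account rests on a few compounds, and the source may have more. Where it says the series, first, only, none or still open, it means among the compounds named here.

Compound 1 `COc1cc2c(Oc3ccc(NC(=O)c4cn(-c5ccccc5)nn4)cc3F)ccnc2cc1OCCCN1CCCCC1` gives 130 nM in a functional assay on A549 cells (Homo sapiens) for cytotoxicity, read by MTT assay, with a stated time of 72 h; a lower number here means a stronger inhibitor, a higher number a weaker inhibitor. Compound 2 `COc1cc2c(Oc3ccc(NC(=O)c4cn(-c5ccccc5C)nn4)cc3F)ccnc2cc1OCCCN1CCCCC1` gives 3230 nM in this assay. Compound 3 `COc1cc2c(Oc3ccc(NC(=O)c4cn(-c5ccccc5)nn4)cc3F)ccnc2cc1OCCCN1CCC(C)CC1` gives 140 nM in this assay.

Compound 3 stands second highest of the three numbers; it and compound 1 lie within the scatter of each other, while compound 2 sits well beyond them. Compound 4 `COc1cc2c(Oc3ccc(NC(=O)c4cn(-c5ccccc5C)nn4)cc3F)ccnc2cc1OCCCN1CCC(C)CC1` is made from compound 3 by methyl in place of hydrogen on an aromatic carbon. The same change on the core without the methyl on the saturated ring carbon gave a 25-fold higher number from compound 1 to compound 2 (1.40 log units; beyond the scatter), a large rise. The other measured step, a 1.1-fold higher number from compound 1 to compound 3 (0.03 log units; within the scatter), stayed within the scatter. A rise of similar size is therefore expected for this assay, a 25-fold higher number from compound 3 to compound 4 (1.40 log units; beyond the scatter). Compound 4 is estimated at 3500 nM, within a range from 1200 nM to 10000 nM.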

Compound 4, half-maximal inhibitory concentration: 3500 nM
Estimate against measurement, compound 4: no gap at the digits printed; the range from low to high includes it.
By their numbers in this assay, from the lowest: compounds 1 and 3 (each within the scatter of the next); then compounds 2 and 4 (each within the scatter of the next).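

In this assay, the rise from phenyl to 2-methylphenyl is no longer a single case, as it returns on a second core, with a 25-fold higher number from compound 3 to compound 4 (1.40 log units; beyond the scatter). The two steps match closely: the same change on two cores in this assay, a 25-fold higher number (1.40 log units; beyond the scatter) from compound 1 to compound 2 and a 25-fold higher number (1.40 log units; beyond the scatter) from compound 3 to compound 4, 1.0-fold (0.00 log units) apart, within the scatter of two such steps With 2-methylphenyl in place, methyl on the saturated ring carbon gives a 1.1-fold higher number from compound 2 to compound 4 (0.03 log units; within the scatter), so across these four compounds the two methyl groups read as independent of each other.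

The compounds shown do not tell whether chlorine, methoxy or an amine at this place would give a rise of similar size. They also leave open what methyl on another carbon of the phenyl ring would do.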